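Swapping a Ring on Compound 2: What to Expect

The source may hold more compounds than are shown below. What is called first, only, known or untested is meant among the compounds shown, and "the series" means these compounds.

compound 1 `COc1ccc(-c2cc(=O)c3c(OC)cc(OC)cc3n2Cc2ccccc2)cc1` — > 17300 nM
compound 2 `COc1cc(OC)c2c(=O)cc(C(=O)Nc3cccc(N4CCCC4)c3)[nH]c2c1` — > 58600 nM

In a functional assay on SEM cells (Homo sapiens) for antiproliferative activity, with a stated time of 72 h (on this read-out higher numbers stand for an effect only at larger amounts of compound and lower numbers for an effect already at smaller amounts), compound 1 reaches only a limit of the test, > 17300 nM, not a true number. Compound 2 likewise gives only a limit in this assay, > 58600 nM. The evidence for compound 1 is the limit of > 17300 nM in this assay, at which 1 of the 2 values shown sits. The evidence for compound 2 is the limit of > 58600 nM in this assay, at which 1 of the 2 values shown sits. Among the compounds with values here, since both stand at limits, no measured step exists to build on. Compound 3 `COc1cc(OC)c2c(=O)cc(C(=O)Nc3cccc(-c4nccs4)c3)[nH]c2c1` carries 1,3-thiazol-2-yl in place of pyrrolidin-1-yl on an aromatic carbon. No direction of change beyond the usual scatter can be foreseen from the data. Compound 3 is expected to give about 60000 nM, between 10000 nM and 300000 nM. That means an expected step that the limit leaves unreadable from compound 2 to compound 3 of no size beyond scatter.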

Compound 3, half-maximal effective concentration: > 54000 nM
Compound 3 ended at the assay's limit (the forecaster's own chance of this, stated with the estimate: 75%); the middle value lies beyond the limit too.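

Within the data shown here, compound 2 and compound 3 both end at limits of this assay, so no step from one to the other can be read. Still open, as far as these compounds go, is whether 1,3-thiazol-2-yl in place of pyrrolidin-1-yl changes the antiproliferative effect at all.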